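Replacing 1H-imidazol-4-yl with fluoro in compound 2

A few compounds are considered here, and "the series" means these few. Any claim that something is new, unique, unknown or untested is made for them only; others in the source may bear on it.

In a functional assay, read by Griess assay, with a stated time of 2.5 h (on this read-out higher numbers stand for weaker inhibition and lower numbers for stronger inhibition), compound 1 (`COc1cc(OC)c(OC)cc1/C=C/C(=O)c1cc(OC(C)=O)ccc1OC(C)=O`) stands at 2.37 ug/mL and compound 3 (`COc1cc(OC)c(-c2cc(=O)c3cc(Cl)ccc3o2)cc1OC`) at 2.15 ug/mL with compound 2 (`COc1cc(OC)c(OC)cc1/C=C/C(=O)c1ccc(-c2c[nH]cn2)cc1`) at 1.97 ug/mL so compound 2 lies within the usual scatter of both. Compound 4 (`COc1cc(OC)c(OC)cc1/C=C/C(=O)c1ccc(F)cc1`) has no number yet. It carries fluoro in place of 1H-imidazol-4-yl on an aromatic carbon of a six-membered aromatic ring of carbon only. Going by the values given here, no measured pair of compounds shows what a change in this place does, so the data offer no direct guide and the starting point is compound 2 at 1.97 ug/mL in this assay without any firm direction. The expected change is a 1.3-fold higher number from compound 2 to compound 4 (0.10 log units; within the scatter) and this estimate stays within the scatter. For compound 4 the estimated value is 2.5 ug/mL with an expected range from 1.1 ug/mL to 6 ug/mL in this wide guess.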

Compound 4, half-maximal inhibitory concentration: 1.96 ug/mL
Compound 4: middle estimate off by 1.3-fold (0.11 log units), on the high side; the range from low to high includes it.
By their numbers in this assay, from the lowest: compounds 4, 2, 3 and 1 (each within the scatter of the next).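

In this assay the swap of 1H-imidazol-4-yl for fluoro gives a 1.0-fold lower number from compound 2 to compound 4 (0.00 log units; within the scatter) and so shows that this place on the ring, para to a large group, can lose a whole five-membered aromatic ring, with its hydrogen-bond donor and acceptor, and keep its reading. A single fluorine atom serves as well here as the larger group. Nothing measured explains why the two groups read alike.

On these data alone, whether an amine, a carboxylic acid or a longer chain would also leave the reading in place stays open.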